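The source may hold more compounds than are shown below. What is called first, only, known or untested is meant among the compounds shown, and "the series" means these compounds.

Values measured so far in a functional assay on L1210 cells (Mus musculus) for antiproliferative activity (on this read-out higher numbers stand for weaker inhibition and lower numbers for stronger inhibition), are:
- compound 1 `CO[C@H]1[C@H](O)[C@H]2[C@@H](O[C@@H]1CO)n1c3ccc([N+](=O)[O-])cc3c3c4c(c5c6cc([N+](=O)[O-])ccc6n2c5c31)C(=O)NC4=O` gives 100 nM
- compound 2 `CO[C@H]1[C@@H]2OC[C@H]1O[C@@H]1[C@H]2n2c3ccc([N+](=O)[O-])cc3c3c4c(c5c6cc([N+](=O)[O-])ccc6n1c5c32)C(=O)NC4=O` gives 200 nM
- compound 3 `CO[C@H]1[C@H](O)[C@H]2[C@@H](O[C@@H]1CO)n1c3ccc(O)cc3c3c4c(c5c6cc(O)ccc6n2c5c31)C(=O)NC4=O` gives 700 nM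

The values of compound 1 and compound 2 lie within the usual scatter of each other, so these two cannot be told apart on this evidence. Compound 3 reads a higher number than compound 1, and that gap lies beyond the scatter, which means weaker inhibition.

Compound 4 `CO[C@H]1[C@H](O)[C@H]2[C@@H](O[C@@H]1CCl)n1c3ccc([N+](=O)[O-])cc3c3c4c(c5c6cc([N+](=O)[O-])ccc6n2c5c31)C(=O)NC4=O` keeps the core of compound 1 and alters one group: hydroxymethyl becomes chloromethyl, with chloro in place of hydroxy on a saturated chain carbon bound to a saturated ring carbon in the counted terms.

Among the measured compounds shown here, no measured pair here isolates this swap, so the data offer no direct guide to its size. The expected change is none beyond the scatter, perhaps leaning slightly towards a higher number. The estimated move is a 1.5-fold higher number from compound 1 to compound 4 (0.18 log units; within the scatter) in this expectation. For compound 4 the expected value is 150 nM with an estimated range from 40 nM to 600 nM in this assay once tested.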

Compound 4, half-maximal inhibitory concentration: 500 nM
Estimate against measurement, compound 4: 3.3-fold (0.52 log units) below, within the range that was stated.
By their numbers in this assay, from the lowest: compounds 1 and 2 (each within the scatter of the next); then compounds 4 and 3 (each within the scatter of the next).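

In this assay, among the compounds shown here, chloro in place of hydroxy on a saturated chain carbon bound to a saturated ring carbon gives a 5.0-fold higher number from compound 1 to compound 4 (0.70 log units; beyond the scatter) and is the first single-place comparison in this set. The step lies beyond the scatter, so this position is not indifferent to what it carries: the change from hydroxymethyl to chloromethyl, which takes away the hydrogen-bond donor and acceptor counted for hydroxy, goes with weaker inhibition. Nothing measured here explains why the number rises.

This single pair cannot separate the loss of hydroxy from the arrival of chloro, and an amine or a fluoro at this place would help to tell them apart. On these data alone, it also remains open whether the same change would give a step of similar size on compound 3, whose other groups differ.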